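The source may report more compounds than this note shows. Statements on the series, on what has been measured and on what is new or still open speak of the compounds shown alone.

Measured compounds in the series:

compound 1, `C=CCCCCCCCS(=O)(=O)/C=C/c1ccc(O)c(O)c1`, 6900 nM
compound 2, `O=S(=O)(/C=C/c1ccc(O)c(O)c1)CC1CCCN1`, 13800 nM
compound 3, `O=S(=O)(/C=C/c1ccc(O)c(O)c1)CC1CCCCO1`, 10800 nM

In a functional assay, read by fluorescence and spectrophotometry, with a stated time of 1 h (on this read-out lower numbers stand for an effect already at smaller amounts and higher numbers for an effect only at larger amounts of compound), compound 2 gives the highest of the three numbers. Its nearest neighbour is compound 3, with a 1.3-fold lower number from compound 2 to compound 3 (0.11 log units; within the scatter). Compound 1 is furthest away, yet the two values still lie within the scatter of each other: compound 2 gives 13800 nM, and compound 1 gives 6900 nM, so the three compounds are not separable on this read-out.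

Compound 4, `C=CCCCCCS(=O)(=O)/C=C/c1ccc(O)c(O)c1`, is unmeasured. It differs from compound 2 as follows: hex-5-en-1-yl in place of pyrrolidin-2-yl on a saturated chain carbon bound to a sulfonyl sulfur. For the measured compounds named here, the only measured step at this position, from a ring to a ring, was a 1.3-fold lower number from compound 2 to compound 3 (0.11 log units; within the scatter), within the scatter. Going by the values given here, compound 1 is the only measured compound without a ring on the saturated chain carbon bound to a sulfonyl sulfur, and its value sits within the scatter of compound 2. Nothing measured therefore points to a change beyond the scatter.

For compound 4 the expected step is a 1.8-fold lower number from compound 2 to compound 4 (0.26 log units; within the scatter), a small shift towards the value of compound 1. Compound 4 is estimated at 7500 nM, with a range from 3000 nM to 18000 nM.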

Compound 4, half-maximal effective concentration: 7100 nM
Estimate against measurement, compound 4: 1.1-fold (0.02 log units) above; measured number inside the range.
By their numbers in this assay, from the lowest: compounds 1, 4, 3 and 2 (each within the scatter of the next).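

In this assay, hex-5-en-1-yl in place of a ring on a saturated chain carbon bound to a sulfonyl sulfur gives a 1.9-fold lower number from compound 2 to compound 4 (0.29 log units; within the scatter) and a 1.5-fold lower number from compound 3 to compound 4 (0.18 log units; within the scatter), so an open chain with no ring now stands at this position alongside pyrrolidin-2-yl and oxan-2-yl without any step beyond the scatter. The same holds for the hydrogen-bond donor and acceptor counted on pyrrolidin-2-yl, since hex-5-en-1-yl carries neither and the step from compound 2 stays within the scatter. Chain length adds no separation either, with vinyl in place of but-3-en-1-yl on a saturated chain carbon, five bonds along the chain from a sulfonyl sulfur, giving a 1.0-fold higher number from compound 1 to compound 4 (0.01 log units; within the scatter), and no supporting data bear on these results.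

The compounds shown leave open whether any group at this position moves the number beyond the scatter, for example a carboxylic acid, a phenyl ring or an open-chain amine. They also leave open how a saturated hexyl chain, with no double bond, would compare with hex-5-en-1-yl in compound 4.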